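The source may report more compounds than this note shows. Statements on the series, on what has been measured and on what is new or still open speak of the compounds shown alone.

Working notes on the series. In a functional assay on A549 cells (Homo sapiens) for antiproliferative activity, read by MTT assay, with a stated time of 48 h (a lower number here means a stronger inhibitor, a higher number a weaker inhibitor), compound 1 `CO[C@]1(C)/C=C/C(=O)/C(CO)=C\C[C@](C)(CCC=C(C)C)/C=C/[C@H]1OC(=O)C=C(C)C` gives 14400 nM. Compound 2 `C=C1/C=C/C(=O)/C(CO)=C\C[C@](C)(CCC=C(C)C)/C=C/[C@H]1OC(=O)C=C(C)C` gives 3090 nM in this assay. Compound 3 `CCN(CC)C/C1=C/C[C@](C)(CCC=C(C)C)/C=C/[C@@H](OC(=O)C=C(C)C)[C@](C)(O)/C=C/C1=O` gives 130 nM in this assay, the lowest of the three numbers; its gaps to compound 2 and to compound 1 both lie beyond the scatter. Compound 4 `CC(C)=CCC[C@]1(C)/C=C/[C@@H](OC(=O)C=C(C)C)[C@](C)(O)/C=C/C(=O)/C(C(=O)N(C(C)C)C(C)C)=C\C1` has not yet been measured. It differs from compound 3 in one place: diisopropylcarbamoyl in place of (diethylamino)methyl on a double-bonded ring carbon. Within the data shown here, no step between two measured compounds covers this change, so the expectation rests on compound 3 alone. A moderate rise in the number is expected, a 3.1-fold higher number from compound 3 to compound 4 (0.49 log units; beyond the scatter), though it may not exceed the scatter. Compound 4 is expected to give 400 nM in this assay, within a range from 100 nM to 2000 nM.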

Compound 4, half-maximal inhibitory concentration: 13500 nM
Beside the measured number, compound 4's estimate is 34-fold (1.53 log units) below it, outside the stated range (above it).
By their numbers in this assay, from the lowest: compound 3; then compound 2; then compounds 4 and 1 (each within the scatter of the next).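

Among these compounds, this is the first single-place step, and replacing (diethylamino)methyl with diisopropylcarbamoyl on the double-bonded ring carbon gives a 100-fold higher number from compound 3 to compound 4 (2.02 log units; beyond the scatter) in this assay on an otherwise unchanged core. The number is therefore highly sensitive to the group at this position, and the low number of compound 3 does not survive this change. Nothing shown gives a cause for the step.

Among the compounds shown here, the single step changes the carbonyl and the groups on nitrogen together, so their separate contributions stay open. Diethylcarbamoyl and (diisopropylamino)methyl groups at this position would separate them.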